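Trimming a Sulfonamide Arm Down to Hydroxymethyl

The compounds below may be only part of what the source reports. "The series", "measured", "known", "first", "only" and "open" are said of these compounds alone.

Compound 2 `O=C1O[C@H]([C@@H](O)Cn2cc(CNS(=O)(=O)c3ccc(F)cc3)nn2)C(OCc2ccccc2)=C1OCc1ccccc1` gives 34700 nM in a functional assay on CFPAC-1 cells (Homo sapiens) for antiproliferative activity, read by MTT assay, with a stated time of 72 h (a higher number here means a weaker inhibitor, a lower number a stronger inhibitor), the lower of the two numbers, though within the scatter of compound 1 `CC(C)(C)c1cn(C[C@H](O)[C@H]2OC(=O)C(OCc3ccccc3)=C2OCc2ccccc2)nn1`, which gives 54900 nM. Compound 3 `O=C1O[C@H]([C@@H](O)Cn2cc(CCO)nn2)C(OCc2ccccc2)=C1OCc1ccccc1` carries hydroxymethyl in place of ((4-fluorophenyl)sulfonyl)amino on a saturated chain carbon bound to an aromatic carbon. Among the compounds with values here, the only measured step touching this part of the molecule is a 1.6-fold lower number from compound 1 to compound 2 (0.20 log units; within the scatter), where a quite different group sat on the same aromatic carbon and the number barely moved. From that single step no shift beyond the scatter is expected, so the estimated step is a 1.2-fold higher number from compound 2 to compound 3 (0.06 log units; within the scatter). Compound 3 is therefore expected to give 40000 nM, within 15000 nM to 110000 nM.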

Compound 3, half-maximal inhibitory concentration: > 100000 nM
Compound 3: only a limit was reported; the forecaster's own chance of this, stated with the estimate: 15%; middle value at least 2.5-fold (0.39 log units) from the limit.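

Compound 3 carries a limit of the assay, not a number: the limit of > 100000 nM in this assay, at which 1 of the 3 values shown sits.

Within the data shown here, what sits on this chain carbon does matter: hydroxymethyl in place of ((4-fluorophenyl)sulfonyl)amino gives an at least 2.8-fold higher number from compound 2 to compound 3 (0.45 log units; beyond the scatter), the only step here printed as beyond the scatter. Setting 2-hydroxyethyl in place of tert-butyl gives an at least 1.8-fold higher number from compound 1 to compound 3 (0.26 log units; that floor lies within the scatter), so that pair alone settles little.

From the compounds shown here alone, it stays open which part of the change counts: the departing fluorophenyl ring, the sulfonyl, or the entering hydroxyl. An amine in place of that hydroxyl, or a longer chain ending in a hydroxyl, would help separate these.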